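A few compounds are considered here, and "the series" means these few. Any claim that something is new, unique, unknown or untested is made for them only; others in the source may bear on it.

Among the measured compounds shown here, in a functional assay on MT4 cells (Homo sapiens) for inhibition (on this read-out higher numbers stand for weaker inhibition and lower numbers for stronger inhibition), compound 3 (`C=C1[C@@H](O)[C@H](n2cnc3c(N)ncnc32)O[C@@H]1CO`) gives 43000 nM, the only number so far. Compound 1 (`C=C1[C@@H](O)[C@H](n2cnc3c(N)nc(N)nc32)O[C@@H]1CO`) gives > 200000 nM, which is a limit of the assay. Compound 2 (`C=C1[C@@H](O)[C@H](n2cnc3c(O)nc(N)nc32)O[C@@H]1CO`) gives > 200000 nM, also a limit. Compound 4 (`C=C1[C@@H](O)[C@H](n2cnc3c(O)ncnc32)O[C@@H]1CO`) differs from compound 3 by hydroxy in place of amino on an aromatic carbon. The same replacement appears as a step that the two limits leave unreadable from compound 1 to compound 2, so it offers no size to carry over. The other measured step, an at least 4.6-fold lower number from compound 1 to compound 3 (0.66 log units; beyond the scatter), is a different change, hydrogen in place of amino. Compound 2 nevertheless remains at > 200000 nM after the replacement, so a move towards weaker inhibition is expected in this assay. The expected step is a 2.8-fold higher number from compound 3 to compound 4 (0.45 log units; beyond the scatter), and a reading at the limit is quite possible. For compound 4 the estimated value is 120000 nM, with an expected range of 40000 nM to 200000 nM.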

Compound 4, half-maximal inhibitory concentration: > 200000 nM
Compound 4: a limit, no number; the forecaster's own chance of this, stated with the estimate: 65%; at least 1.6-fold (0.22 log units) between middle value and limit.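

Hydroxy in place of amino on an aromatic carbon could not be sized between compound 1 and compound 2, but it now gives an at least 4.6-fold higher number from compound 3 to compound 4 (0.66 log units; beyond the scatter) in this assay as the only readable measure of this change. In this pair, the amino group gives stronger inhibition than hydroxy, although compound 4 sits at a limit. As far as these compounds go, the step from compound 2 to compound 4 cannot be read, and the full size of the step to compound 4 also stays unknown: the limit of > 200000 nM in this assay, at which 3 of the 4 values shown sit.

From the compounds shown here alone, whether methylamino or chlorine on this aromatic carbon would match the amino group of compound 3 remains open.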